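A few compounds are considered here, and "the series" means these few. Any claim that something is new, unique, unknown or untested is made for them only; others in the source may bear on it.

Compound 1 `Cc1nc(-c2c(F)cccc2-c2ccc([C@@H](C)Nc3nccc(Cl)c3NC(=O)CC#N)cc2)no1` gives 50% in an in vivo ADME assay on the whole organism (strain Sprague-Dawley) for pharmacokinetics, with Rattus norvegicus as the target, at a dose of 10 mg/kg by the oral route (on this read-out lower numbers stand for lower oral bioavailability and higher numbers for higher oral bioavailability), and stands lowest of the three numbers measured there. Compound 2 `C[C@@H](Nc1nccc(Cl)c1NC(=O)CC#N)c1ccc(-c2cccc(F)c2-c2nnn(C)n2)cc1` gives 73% and compound 3 `C[C@@H](Nc1nccc(Cl)c1NC(=O)CC#N)c1ccc(-c2cccc(F)c2C#N)cc1` gives 80%. Compound 4 `C[C@@H](Nc1nccc(Cl)c1NC(=O)CC#N)c1ccc(-c2cccc(F)c2C(F)(F)F)cc1` has not yet been measured. It differs from compound 1 as follows trifluoromethyl in place of 5-methyl-1,2,4-oxadiazol-3-yl on an aromatic carbon and the new group sits ortho to a fluoro group and ortho to a large group on a six-membered aromatic ring of carbon only.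

Within the data shown here, two measured steps bear on this change, since each also removes the 5-methyl-1,2,4-oxadiazol-3-yl group from the same aromatic carbon: a number 23 percentage points higher from compound 1 to compound 2 (beyond the scatter) and a number 30 percentage points higher from compound 1 to compound 3 (beyond the scatter). Both lie beyond the scatter and point the same way, while the gap between compound 2 and compound 3 is a number 7 percentage points higher from compound 2 to compound 3 (within the scatter). A step of similar size, upward, is therefore expected for compound 4, and it is estimated to reach 72%, with a range from 52% to 90%, which corresponds to an expected step of a number 22 percentage points higher from compound 1 to compound 4 (beyond the scatter).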

Compound 4, oral bioavailability: 52%
For compound 4 the middle estimate is 20 percentage points above the measured one, and the stated range covers the measured number.
By their numbers in this assay, from the lowest: compounds 1 and 4 (each within the scatter of the next); then compounds 2 and 3 (each within the scatter of the next).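

In this assay, trifluoromethyl in place of 5-methyl-1,2,4-oxadiazol-3-yl gives a number 2 percentage points higher from compound 1 to compound 4 (within the scatter) and so does not share the rise seen with the two earlier replacements, which shows that losing the 5-methyl-1,2,4-oxadiazol-3-yl group does not on its own raise the number. At this aromatic carbon the entering group matters, since trifluoromethyl in place of cyano gives a number 28 percentage points lower from compound 3 to compound 4 (beyond the scatter) and trifluoromethyl in place of 2-methyl-2H-tetrazol-5-yl gives a number 21 percentage points lower from compound 2 to compound 4 (beyond the scatter) in the same read-out. Nothing available explains this split into two pairs of compounds.

The compounds shown leave open whether an amine, a carboxylic acid or a methoxy group on this carbon would fall with the upper pair or the lower pair. They also leave open whether the split would persist without the fluoro group on that ring.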